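Series notes: lactone to carboxylic acid on the shared core

The source may report more compounds than this note shows. Statements on the series, on what has been measured and on what is new or still open speak of the compounds shown alone.

Measured so far in a functional assay on HL-60 cells (Homo sapiens) for antiproliferative activity, read by trypan blue exclusion; a higher number here means a weaker inhibitor of growth, a lower number a stronger inhibitor of growth:
compound 1, `C=C1CC[C@@H]2[C@](C)(CO)[C@H](O)CC[C@@]2(C)[C@@H]1CCC1=CCOC1=O`, 25500 nM
compound 2, `C=C1CC[C@@H]2[C@](C)(CO)[C@H](O)CC[C@@]2(C)[C@@H]1/C=C/C1=CC(OC)OC1=O`, 26400 nM

In this assay compound 2 and compound 1 give numbers that lie within the scatter of each other, so nothing separates them. Compound 3, `C=C1CC[C@@H]2[C@](C)(CO)[C@H](O)CC[C@@]2(C)[C@@H]1/C=C/C(=O)O`, is not yet measured. It differs from compound 2 as follows: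

a group of 3 heavy atoms (1 carbon, 2 oxygen; no ring) in place of a group of 8 heavy atoms (5 carbon, 3 oxygen; one five-membered non-aromatic ring with 1 hetero atom), on a double-bonded chain carbon bound to a double-bonded chain carbon

Among the measured compounds shown here, no step between measured compounds is available to anchor this change, and both measured numbers sit at the weak end. Compound 3 is expected to give a number of similar or somewhat larger size, with a step of a 1.7-fold higher number from compound 2 to compound 3 (0.23 log units; within the scatter) that may or may not exceed the scatter. Compound 3 is estimated at 45000 nM in this assay, with a range from 15000 nM to 130000 nM; a limit rather than a number is a real possibility.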

Compound 3, concentration for 50% growth inhibition: 28800 nM
The estimate for compound 3 lay 1.6-fold (0.19 log units) above the measured number; measured number inside the range.
By their numbers in this assay, from the lowest: compounds 1, 2 and 3 (each within the scatter of the next).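

In this assay the carboxy group takes the place of the ring-bearing group of compound 2 with a 1.1-fold higher number from compound 2 to compound 3 (0.04 log units; within the scatter) and no further change, so at this double-bonded chain carbon the five-membered ring can go without the number leaving the scatter. Read on the saturated ring carbon, where the whole side chain differs, the result is a 1.1-fold higher number from compound 1 to compound 3 (0.05 log units; within the scatter) and the same holds, so among these three compounds neither the ring nor the size of the group separates the numbers. Nothing measured bears on why the numbers stay together.

Open, on these data alone, is whether any group at this place gives a number beyond the scatter of these three, for example a methyl ester, a primary amide or an amine in place of the carboxy group. Also open, as far as these compounds go, is what a longer chain carrying the carboxy group would give on the shared core.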